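This account rests on a few compounds, and the source may have more. Where it says the series, first, only, none or still open, it means among the compounds named here.

Measured in a functional assay on HCT-15 cells (Homo sapiens) for antiproliferative activity, read by XTT assay; on this read-out lower numbers stand for stronger inhibition and higher numbers for weaker inhibition:
compound 1 `O=c1c(Cc2coc3cccc(OCC4CCCCC4)c3c2=O)coc2ccccc12`: 4240 nM
compound 2 `COc1ccc2c(=O)c(Cc3coc4cccc(OCC5CCCCC5)c4c3=O)coc2c1`: 1450 nM
compound 3 `Cc1ccc2c(=O)c(Cc3coc4cccc(OCC5CCCCC5)c4c3=O)coc2c1`: 2220 nM

Compound 3 holds the second highest of the three numbers; its nearest neighbour is compound 2 and its furthest compound 1, and both gaps lie within the scatter, so no order among the three is settled. Compound 4 `O=c1c(Cc2coc3cccc(OCC4CCCCC4)c3c2=O)coc2cc(O)ccc12` differs from compound 3 by hydroxy in place of methyl on an aromatic carbon. Going by the values given here, the steps that bear on this are a 1.9-fold lower number from compound 1 to compound 3 (0.28 log units; within the scatter) and a 2.9-fold lower number from compound 1 to compound 2 (0.47 log units; beyond the scatter), with a 1.5-fold higher number from compound 2 to compound 3 (0.18 log units; within the scatter) between the two substituted compounds. Among the compounds with values here, all are small, and no measured compound carries a hydroxy at this place, so nothing separates hydroxy from methyl or methoxy here. The step into compound 4 is therefore expected to stay within the scatter, a 1.2-fold lower number from compound 3 to compound 4 (0.07 log units; within the scatter). Compound 4 is estimated at 1900 nM in this assay, range 700 nM to 5000 nM.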

Compound 4, half-maximal inhibitory concentration: 2110 nM
Compound 4: the middle estimate sits 1.1-fold (0.05 log units) below what was measured, and the stated range covers the measured number.
By their numbers in this assay, from the lowest: compounds 2, 4, 3 and 1 (each within the scatter of the next, the first and the last beyond it).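

In this assay, hydroxy on this aromatic carbon cannot be told apart from methyl (a 1.1-fold lower number from compound 3 to compound 4 (0.02 log units; within the scatter)) or from methoxy (a 1.5-fold higher number from compound 2 to compound 4 (0.16 log units; within the scatter)), so the hydrogen-bond donor that enters with hydroxy leaves no readable mark here. Hydroxy in place of hydrogen also stays within the scatter (a 2.0-fold lower number from compound 1 to compound 4 (0.30 log units; within the scatter)), while the methoxy step from the same parent lies beyond it (a 2.9-fold lower number from compound 1 to compound 2 (0.47 log units; beyond the scatter)). No evidence bears on these results.

Going by these compounds, whether an amine, a carboxylic acid or a longer chain such as ethoxy at this place would stay level with these groups remains open. Equally open, on these data alone, is whether hydroxy would read the same on another carbon of this ring.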